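The source may report more compounds than this note shows. Statements on the series, on what has been measured and on what is new or still open speak of the compounds shown alone.

Compound 2 `COc1ccc(-n2cnc3cnc(-c4ccc(F)cc4C)cc32)cc1` and compound 1 `COc1ccc(-n2cnc3cnc(-c4ccc(F)cc4C)cc32)cc1OC` share a core and differ in a single place: methoxy in place of hydrogen on an aromatic carbon. In a functional assay on HL-60 cells (Homo sapiens) for activation, read by flow cytometry, with a stated time of 4 days (on this read-out lower numbers stand for an effect already at smaller amounts and higher numbers for an effect only at larger amounts of compound), compound 2 gives 6 nM, while compound 1 gives 15 nM, a step of a 2.5-fold higher number from compound 2 to compound 1 (0.40 log units; beyond the scatter). Compound 3 `Fc1ccc(-c2cc3c(cn2)ncn3-c2ccc(OC(F)F)cc2)cc1` rests on a different core, and the difference between the two cores is not broken down here. In this assay compound 3 gives 10000 nM, the highest of the three numbers. Compound 4 `COc1cc(F)ccc1-c1cc2c(cn1)ncn2-c1ccc(OC(F)F)cc1` arises from compound 3 by the same kind of change: methoxy in place of hydrogen on an aromatic carbon. The surroundings differ, though: in compound 4 the entering methoxy sits ortho to a large group and meta to a fluoro group, whereas in compound 1 it sits ortho to a methoxy group and meta to a large group. The earlier step was modest, so no large move is expected on that ground alone. For compound 4 a step of a 3.3-fold lower number from compound 3 to compound 4 (0.52 log units; beyond the scatter) is expected. Compound 4 is estimated at 3000 nM, with a likely range from 300 nM to 15000 nM.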

Compound 4, half-maximal effective concentration: 93 nM
Estimate against measurement, compound 4: 32-fold (1.51 log units) above; the whole stated range lies above it.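

In this assay, methoxy in place of hydrogen on an aromatic carbon gives a 110-fold lower number from compound 3 to compound 4 (2.03 log units; beyond the scatter), a large step. Set beside the earlier step on the other core, it does not repeat it: the same change on two cores in this assay, a 2.5-fold higher number (0.40 log units; beyond the scatter) from compound 2 to compound 1 and a 110-fold lower number (2.03 log units; beyond the scatter) from compound 3 to compound 4, 270-fold (2.43 log units) apart, beyond the scatter of two such steps. The change thus carried over between these two cores in neither size nor direction, but these two pairs cannot separate the effect of the core from that of the surroundings of the entering methoxy, which in compound 4 sits ortho to a large group and meta to a fluoro group.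

The compounds shown leave open whether a hydroxy group, an ethoxy group or an amine entering at that same place would give a step like the one to compound 4. They also leave open how the same change would behave on any further core.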